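The source may report more compounds than this note shows. Statements on the series, on what has been measured and on what is new or still open speak of the compounds shown alone.

Of the compounds shown here, three built on one shared core have been measured in a functional assay on NCI-H1975 cells (Homo sapiens) for antiproliferative activity, read by MTT assay, with a stated time of 72 h; on this read-out higher numbers stand for weaker inhibition and lower numbers for stronger inhibition. Compound 1 `C#Cc1cccc(Nc2ncnc3ccc(NC(=S)Nc4ccc(S(N)(=O)=O)cc4)cc23)c1` gives 13400 nM, compound 2 `NS(=O)(=O)c1ccc(NC(=S)Nc2ccc3ncnc(Nc4ccc(Cl)c(C(F)(F)F)c4)c3c2)cc1` gives 11800 nM, and compound 3 `NS(=O)(=O)c1ccc(NC(=S)Nc2ccc3ncnc(Nc4ccc(F)c(Br)c4)c3c2)cc1` gives 9980 nM. Compound 3 sits at the low end of the three, yet a 1.3-fold lower number from compound 1 to compound 3 (0.13 log units; within the scatter) and a 1.2-fold lower number from compound 2 to compound 3 (0.07 log units; within the scatter) both lie within the scatter, as does a 1.1-fold lower number from compound 1 to compound 2 (0.06 log units; within the scatter). Compound 4 `NS(=O)(=O)c1ccc(NC(=S)Nc2ccc3ncnc(Nc4cccc(Cl)c4F)c3c2)cc1` carries 3-chloro-2-fluorophenyl in place of 3-bromo-4-fluorophenyl on a nitrogen on an aromatic ring. The measured steps that bear on this change are the exchanges of the aryl group on the same nitrogen, a 1.3-fold lower number from compound 1 to compound 3 (0.13 log units; within the scatter) and a 1.2-fold lower number from compound 2 to compound 3 (0.07 log units; within the scatter), neither of which moved this assay beyond the scatter. Compound 4 is therefore expected to show no step beyond the scatter, a 1.0-fold higher number from compound 3 to compound 4 (0.00 log units; within the scatter), in this assay. Compound 4 is estimated at 10000 nM, with a range from 5000 nM to 20000 nM.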

Compound 4, half-maximal inhibitory concentration: 25100 nM
For compound 4 the middle estimate is 2.5-fold (0.40 log units) below the measured one; the whole stated range lies below it.
By their numbers in this assay, from the lowest: compounds 3, 2, 1 and 4 (each within the scatter of the next, the first and the last beyond it).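

In this assay, within the data shown here, the aryl group on this nitrogen can move the read-out after all: the exchange gives a 2.5-fold higher number from compound 3 to compound 4 (0.40 log units; beyond the scatter) and a 2.1-fold higher number from compound 2 to compound 4 (0.33 log units; beyond the scatter) as the first steps beyond the scatter, whereas a 1.9-fold higher number from compound 1 to compound 4 (0.27 log units; within the scatter) stays within it, so compound 1 is not separated from compound 4. Nothing given here accounts for the change from 3-bromo-4-fluorophenyl to 3-chloro-2-fluorophenyl. Open, from the compounds shown here alone, is whether the higher number follows the moved fluorine or the exchange of bromine for chlorine, as both change in this one step. Also open, going by these compounds, is how an aryl group carrying an amine or a carboxylic acid would read on this nitrogen.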